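The compounds below may be only part of what the source reports. "The series", "measured", "known", "first", "only" and "open" are said of these compounds alone.

Measured so far in a functional assay on MDA-MB-468 cells (Homo sapiens) for antiproliferative activity, read by sulforhodamine B assay, with a stated time of 72 h; on this read-out higher numbers stand for weaker inhibition and lower numbers for stronger inhibition:
compound 1 `FC(F)(F)c1cccc(/C=C\c2cc3ccccc3nc2Cl)c1` gives 3700 nM
compound 2 `COc1ccc2nc(Cl)c(/C=C\c3cc(C(F)(F)F)cc(C(F)(F)F)c3)cc2c1` gives 5790 nM
compound 3 `FC(F)(F)c1cc(/C=C\c2cc3ccccc3nc2Cl)cc(C(F)(F)F)c1` gives 10500 nM

Compound 3 and compound 2 stand together at the top of these numbers, and only compound 1 lies clearly apart from compound 3. The next compound, compound 4 `FC(F)(F)c1cc(/C=C\c2cc3ccc(Cl)cc3nc2Cl)cc(C(F)(F)F)c1`, is compound 3 with a single change: chloro in place of hydrogen on an aromatic carbon of the shared core.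

For the measured compounds named here, no measured step involves chloro, so the expectation has to lean on two related changes. Hydrogen in place of methoxy on an aromatic carbon gave a 1.8-fold higher number from compound 2 to compound 3 (0.26 log units; within the scatter) and is the closer guide, as it also alters the shared core. Trifluoromethyl in place of hydrogen on an aromatic carbon gave a 2.8-fold higher number from compound 1 to compound 3 (0.45 log units; beyond the scatter) and counts as modest. Neither suggests a large change, so in this assay a small step is expected, quite possibly none beyond the scatter. A slight lean towards a lower number is expected, since a substituted core is seen in compound 2 at 5790 nM (a single example). The estimated change is a 1.3-fold lower number from compound 3 to compound 4 (0.12 log units; within the scatter) and remains uncertain. Compound 4 is estimated at 8000 nM (range 3000 nM to 20000 nM).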

Compound 4, half-maximal inhibitory concentration: > 50000 nM
Compound 4 ended at the assay's limit; the forecaster's own chance of this, stated with the estimate: 10%; at least 6.2-fold (0.79 log units) between middle value and limit.
By their numbers in this assay, from the lowest: compounds 1, 2 and 3 (each within the scatter of the next, the first and the last beyond it). At a limit, above all of these: compound 4.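

In this assay, chloro in place of hydrogen on this aromatic carbon of the shared core gives an at least 4.7-fold higher number from compound 3 to compound 4 (0.67 log units; beyond the scatter), so adding one heavy atom at this position is enough to produce a step beyond the scatter. The only earlier change on the core, hydrogen in place of methoxy, gave a 1.8-fold higher number from compound 2 to compound 3 (0.26 log units; within the scatter), so the core had not yet shown that a single substituent could matter beyond the scatter. The real size of the new step remains unknown because compound 4 stands at a limit of the assay rather than at a measured number: the limit of > 50000 nM in this assay, at which 1 of the 4 values shown sits.

On these data alone, what stays open is whether this loss of inhibition belongs to chloro itself or would also follow from another group on the same carbon, such as fluoro, methyl or an amine. For the compounds shown here, also open is whether chloro on the other carbons of this ring, or on the core of compound 1 with its single trifluoromethyl group, would give a step of similar size.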